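This account rests on a few compounds, and the source may have more. Where it says the series, first, only, none or still open, it means among the compounds named here.

Measured so far:
Compound 1, `COc1ccc(-c2ssc(=S)c2-c2cc(OC)c(OC)c(OC)c2)cc1[N+](=O)[O-]`: > 100000 nM
Compound 2, `COc1ccc(-c2ssc(=S)c2-c2cc(OC)c(OC)c(OC)c2)cc1N`: 327 nM
Compound 3, `COc1ccc(-c2c(-c3cc(OC)c(OC)c(OC)c3)ssc2=O)cc1[N+](=O)[O-]`: > 100000 nM

The three were tested in a functional assay on KB cells (Homo sapiens) for antiproliferative activity, read by MTT assay, with a stated time of 72 h; on this read-out lower numbers stand for stronger inhibition and higher numbers for weaker inhibition. For compound 1 the result > 100000 nM is a limit of the assay, not a number. Compound 2 gives 327 nM, and the step from one to the other, an at least 300-fold lower number from compound 1 to compound 2 (2.48 log units; beyond the scatter), is the one clear move in the set; it rests on the change (amino in place of nitro on an aromatic carbon). For compound 3 the result > 100000 nM is likewise a limit, and the limit of > 100000 nM in this assay, at which 2 of the 3 values shown sit, is the point where two of the three readings sit. How the core of compound 3 differs from that of compound 1 is not broken down here.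

Compound 4, `COc1ccc(-c2c(-c3cc(OC)c(OC)c(OC)c3)ssc2=O)cc1N`, has not been measured. Going by the values given here, it differs from compound 3 by amino in place of nitro on an aromatic carbon, the same kind of change as the one from compound 1 to compound 2. By analogy with an at least 300-fold lower number from compound 1 to compound 2 (2.48 log units; beyond the scatter), compound 4 is expected to show a step of an at least 200-fold lower number from compound 3 to compound 4 (2.30 log units; beyond the scatter) in this assay. Compound 4 is therefore estimated at 500 nM, in a range from 100 nM to 10000 nM.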

Compound 4, half-maximal inhibitory concentration: > 100000 nM
Compound 4: no number, only a limit; the forecaster's own chance of this, stated with the estimate: 25%; at least 200-fold (2.30 log units) between middle value and limit.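

Going by these compounds alone, compound 3 and compound 4 both stay at a limit rather than a number, so no step between them can be read: the limit of > 100000 nM in this assay, at which 3 of the 4 values shown sit. The compounds shown leave open whether amino in place of nitro on an aromatic carbon changes the reading at all on the core of compound 3, as it does on the core of compound 1.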